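The source may report more compounds than this note shows. Statements on the series, on what has been measured and on what is new or still open speak of the compounds shown alone.

Compound 1: `COc1cc2c(Oc3ccc(NC(=O)N/N=C/c4ccc(C(F)(F)F)cc4)cc3F)ccnc2cc1OCCCN1CCCCC1` — 660 nM
Compound 2: `COc1cc2c(Oc3ccc(NC(=O)N/N=C/c4cc5ccccc5[nH]4)cc3F)ccnc2cc1OCCCN1CCCCC1` — 820 nM

In a functional assay on HT-29 cells (Homo sapiens) for cytotoxicity, read by MTT assay, with a stated time of 72 h (on this read-out lower numbers stand for stronger inhibition and higher numbers for weaker inhibition), compound 1 gives 660 nM and compound 2 gives 820 nM. Among the measured compounds shown here, compound 2 stands alongside compound 1, the only other measured compound, and the two differ by a 1.2-fold higher number from compound 1 to compound 2 (0.09 log units; within the scatter), so the two numbers cannot be told apart. Compound 3 `COc1cc2c(Oc3ccc(NC(=O)N/N=C/c4cccs4)cc3F)ccnc2cc1OCCCN1CCCCC1` has not yet been measured. It differs from compound 2 by thiophen-2-yl in place of 1H-indol-2-yl on a carbon with a double bond to nitrogen. For the measured compounds named here, only one measured step bears on this position, a 1.2-fold higher number from compound 1 to compound 2 (0.09 log units; within the scatter), where exchanging the group on the same carbon left the number essentially where it was. Going by the values given here, no measured compound carries a thiophen-2-yl group, so the expectation rests on that single small step alone. The expected change is a 1.0-fold lower number from compound 2 to compound 3 (0.01 log units; within the scatter), that is, no step beyond the scatter in either direction. Compound 3 is therefore estimated at 800 nM, with a range from 350 nM to 1800 nM.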

Compound 3, half-maximal inhibitory concentration: 770 nM
Estimate against measurement, compound 3: 1.0-fold (0.02 log units) above; measured number inside the range.
By their numbers in this assay, from the lowest: compounds 1, 3 and 2 (each within the scatter of the next).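

In this assay, thiophen-2-yl replaces 1H-indol-2-yl, losing the six-membered aromatic ring of carbon and the hydrogen-bond donor, and the result is a 1.1-fold lower number from compound 2 to compound 3 (0.03 log units; within the scatter). Set against the 4-(trifluoromethyl)phenyl group, the same thiophen-2-yl gives a 1.2-fold higher number from compound 1 to compound 3 (0.07 log units; within the scatter), so all three aromatic groups on this carbon with a double bond to nitrogen are now indistinguishable in this cell assay, whether or not they carry that donor or six-membered ring. No further data here offer an explanation for this flat result.

From the compounds shown here alone, all three groups at this position are aromatic rings, so it remains open whether a cyclohexyl ring, a carboxylic acid or a chain bearing an amine would move the number. Going by these compounds, it also remains open whether this flatness would hold with a change elsewhere on the shared core.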